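The source may hold more compounds than are shown below. What is called first, only, known or untested is meant among the compounds shown, and "the series" means these compounds.

Compounds measured in a functional assay on CHO cells for antagonist activity at C-C chemokine receptor type 4 (Homo sapiens), read by GTPgammaS binding; on this read-out higher numbers stand for weaker inhibition and lower numbers for stronger inhibition:
compound 1 `CC(=O)NCc1cccc(Cn2nc(NS(=O)(=O)c3ccc(Cl)s3)c3c(C#N)cccc32)c1` gives 316 nM
compound 2 `COc1cccc2c1c(NS(=O)(=O)c1ccc(Cl)s1)nn2Cc1cccc(CNC(=O)C2COC2)c1` gives 20 nM

Compound 2 holds the lower of the two numbers in this assay; the gap from compound 1 to compound 2 is beyond the scatter, and since the two differ in more than one place, only the values themselves speak. Compound 3 `COc1cccc2c1c(NS(=O)(=O)c1ccc(Cl)s1)nn2Cc1cccc(CNC(=O)C2CCO2)c1` differs from compound 2 by oxetan-2-yl in place of oxetan-3-yl on a carbonyl carbon. Within the data shown here, no comparable step has been measured. A change of this kind is expected to leave the number roughly where it is, so the step of a 1.3-fold higher number from compound 2 to compound 3 (0.10 log units; within the scatter) is expected to stay within the scatter. Compound 3 is therefore estimated at 25 nM, in the range 8 nM to 80 nM.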

Compound 3, half-maximal inhibitory concentration: 31.6 nM
For compound 3 the middle estimate is 1.3-fold (0.10 log units) below the measured one, within the range that was stated.
By their numbers in this assay, from the lowest: compounds 2 and 3 (each within the scatter of the next); then compound 1.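

In this assay putting oxetan-2-yl in place of oxetan-3-yl on the carbonyl carbon gives a 1.6-fold higher number from compound 2 to compound 3 (0.20 log units; within the scatter) so the two attachments of the oxetane cannot be told apart at this position. Among these compounds, this is the first comparison that differs in one place, and it touches only how the same four-membered ring is joined. No evidence bears on this result.

On these data alone, it remains open whether cyclobutyl, an azetidine or an open chain such as methoxymethyl on the same carbonyl carbon would read alike.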